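Group swap on the saturated ring carbon: compound 4

The source may report more compounds than this note shows. Statements on the series, on what has been measured and on what is new or still open speak of the compounds shown alone.

Measured compounds:
compound 1 `COc1cc(C2=NN(C(C)=O)C(c3c(Cl)cccc3Cl)O2)cc(OC)c1OC`: 5.1%
compound 2 `COc1ccc(OC)c(C2OC(c3cc(OC)c(OC)c(OC)c3)=NN2C(C)=O)c1`: 37.2%
compound 3 `COc1cc(C2=NN(C(C)=O)C(c3cc(OC)c(OC)c(OC)c3)O2)cc(OC)c1OC`: -1.8%

In a functional assay on PC-3 cells (Homo sapiens) for antiproliferative activity, read by MTT assay, tested at 1 uM (a higher number here means a stronger effect of the compound at the concentration tested, a lower number a weaker effect), compound 2 stands highest of the three numbers, with compound 1 nearest and compound 3 furthest, both beyond the scatter. Among the measured compounds shown here, the one single-point step known is a number 32.1 percentage points higher from compound 1 to compound 2 (beyond the scatter), a large one, which bears directly on the present change since it alters the same position. Compound 4 `COc1cc(C2=NN(C(C)=O)C(c3ccc(Cl)c([N+](=O)[O-])c3)O2)cc(OC)c1OC` differs from compound 2 by 4-chloro-3-nitrophenyl in place of 2,5-dimethoxyphenyl on a saturated ring carbon. With both other groups seen at this carbon giving small numbers, compound 4 is expected to fall back toward those, a downward step of a number 25.2 percentage points lower from compound 2 to compound 4 (beyond the scatter) beyond the scatter. Compound 4 is estimated at 12%, in the range -5% to 35%.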

Compound 4, a percentage reported as inhibition, at one concentration (the size of the read-out at that concentration, not a potency): 43.3%
Beside the measured number, compound 4's estimate is 31.3 percentage points below it; the measured number lies above the stated range.
By their numbers in this assay, from the lowest: compounds 3 and 1 (each within the scatter of the next); then compounds 2 and 4 (each within the scatter of the next).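

In this assay, two quite different aryl groups on the saturated ring carbon give numbers that cannot be told apart: a number 6.1 percentage points higher from compound 2 to compound 4 (within the scatter), although 4-chloro-3-nitrophenyl and 2,5-dimethoxyphenyl have no substituent in common. The low number of compound 1 now stands against two groups rather than one, with a number 38.2 percentage points higher from compound 1 to compound 4 (beyond the scatter) as a second large step away from 2,6-dichlorophenyl. Nothing available explains why these groups behave alike.

Open, as far as these compounds go, is whether the chloro or the nitro group alone would hold the number of compound 4. Also open, from the compounds shown here alone, is how an amine or a carboxylic acid on this phenyl ring would read at this position.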